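Cyclopentylmethyl ester expected to sit with its neighbours

This account rests on a few compounds, and the source may have more. Where it says the series, first, only, none or still open, it means among the compounds named here.

Among the measured compounds shown here, in an assay on isolated protein for inhibition of Rho-associated protein kinase 2 (Homo sapiens), read by radiometric assay (a lower number here means a stronger inhibitor, a higher number a weaker inhibitor), compound 2 `NCc1ccc(C(=O)Nc2ccncc2)cc1-c1cccc(C(=O)OCc2ccccc2)c1` gives 45 nM and stands level with the only other measured compound, since compound 1 `NCc1ccc(C(=O)Nc2ccncc2)cc1-c1cccc(C(=O)OCC2CCCCC2)c1` gives 48 nM and the step of a 1.1-fold lower number from compound 1 to compound 2 (0.03 log units; within the scatter) lies within the scatter. Compound 3 `NCc1ccc(C(=O)Nc2ccncc2)cc1-c1cccc(C(=O)OCC2CCCC2)c1` differs from compound 2 by cyclopentyl in place of phenyl on a saturated chain carbon bound to an oxygen next to a carbonyl group. For the measured compounds named here, the one measured step that bears on this change, phenyl for cyclohexyl at the same place, was flat, so the expected step in this assay is a 1.1-fold higher number from compound 2 to compound 3 (0.05 log units; within the scatter), nothing beyond the scatter. Compound 3 is therefore estimated at 50 nM, with a range from 22 nM to 115 nM.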

Compound 3, half-maximal inhibitory concentration: 5 nM
For compound 3 the middle estimate is 10-fold (1.00 log units) above the measured one; the whole stated range lies above it.
By their numbers in this assay, from the lowest: compound 3; then compounds 2 and 1 (each within the scatter of the next).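

Phenyl and cyclohexyl gave no hint that this place was sensitive, but cyclopentyl separates clearly from both in this assay (a 9.0-fold lower number from compound 2 to compound 3 (0.95 log units; beyond the scatter)) and (a 9.6-fold lower number from compound 1 to compound 3 (0.98 log units; beyond the scatter)). On a saturated chain carbon bound to an oxygen next to a carbonyl group, the choice of ring can therefore shift the number well beyond the scatter. No evidence at hand accounts for this shift. Whether cyclobutyl or cycloheptyl would match cyclopentyl remains open, so the compounds shown do not settle whether ring size alone matters. As far as these compounds go, an open pentyl chain or an amine at this place also remains untested here.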